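The source may hold more compounds than are shown below. What is called first, only, known or untested is meant among the compounds shown, and "the series" means these compounds.

Measured so far in an assay on isolated protein for inhibition of leukotriene B4 receptor 1 (Homo sapiens), tested at 10 uM; a lower number here means less inhibition, a higher number more inhibition at the concentration tested (going by the name of the read-out):
compound 1 `C=CCc1cc(C(C)=O)c(O)cc1OCCCC#N` gives 47%
compound 2 `CCc1cc(C(C)=O)c(O)cc1OCCCC(C)(C)C(=O)O` gives 89%

Compound 2 stands highest of the two numbers; its nearest neighbour is compound 1, whose value lies lower by more than the usual scatter, so the two compounds are clearly told apart. Within the data shown here, no pair of measured compounds differs in a single place, so no step can be read off.

Compound 3 `CCc1cc(C(C)=O)c(O)cc1OCCCCc1nnn[nH]1` is not yet measured. It differs from compound 2 in one place: (1H-tetrazol-5-yl)methyl in place of 1-carboxy-1-methylethyl on a saturated chain carbon, three bonds along the chain from an oxygen on an aromatic ring. Among the measured compounds shown here, with no comparable step among the measured compounds, the size of the step in this assay can only be projected; the expectation is a small loss, or none beyond the scatter. For compound 3 the estimate is 75%, with a range from 45% to 95%. The expected step is a number 14 percentage points lower from compound 2 to compound 3 (beyond the scatter).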

Compound 3, a percentage reported as inhibition, at one concentration (the size of the read-out at that concentration, not a potency): 49%
Compound 3: the middle estimate sits 26 percentage points above what was measured; low and high end bracket the measured number.
By their numbers in this assay, from the lowest: compounds 1 and 3 (each within the scatter of the next); then compound 2.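

In this assay, among these compounds, the exchange of 1-carboxy-1-methylethyl for (1H-tetrazol-5-yl)methyl gives a number 40 percentage points lower from compound 2 to compound 3 (beyond the scatter), the first step that can be read. On this saturated chain carbon, three bonds along the chain from an oxygen on an aromatic ring, two groups with the same count of heavy atoms are therefore not interchangeable, although compound 3 still gives 49%. Nothing at hand bears on the reason for the size of this step.

Among the compounds shown here, the single change removes the carboxylic acid and the branching methyl groups together and brings in the tetrazole ring, so their shares in the step stay unresolved. An unbranched carboxylic acid on the same chain would separate these parts, and a longer chain carrying the tetrazole would test the reach of the ring.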